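The source may hold more compounds than are shown below. What is called first, only, known or untested is meant among the compounds shown, and "the series" means these compounds.

Compound 3 `Oc1ccc(-c2cc(-c3cccc(OC(F)(F)F)c3)cc(-c3ccccc3O)n2)cc1` is the starting point here. In a functional assay on DU-145 cells (Homo sapiens) for inhibition (on this read-out lower numbers stand for stronger inhibition and higher numbers for weaker inhibition), compound 3 reaches only a limit of the assay, > 50000 nM. Its two close relatives set the frame. Compound 2 `Oc1ccccc1-c1cc(-c2cccc(OC(F)(F)F)c2)cc(-c2ccccc2O)n1` gives in this assay a value of 7470 nM. Compound 1 `Oc1ccc(-c2cc(-c3cccc(C(F)(F)F)c3)cc(-c3ccccc3O)n2)cc1` sits in this assay at the limit > 50000 nM. The step that the two limits leave unreadable from compound 1 to compound 3 therefore cannot be read. The step of an at least 6.6-fold higher number from compound 2 to compound 3 (0.82 log units; beyond the scatter), by contrast, is a clear loss of inhibition. Compound 4 `Oc1ccc(-c2cc(-c3cccc(OC(F)(F)F)c3)cc(-c3ccc(O)cc3)n2)cc1` differs from compound 3 by 4-hydroxyphenyl in place of 2-hydroxyphenyl on an aromatic carbon. This repeats the kind of change seen between compound 2 and compound 3, which carried the number past the limit at which two of the three values stand (the limit of > 50000 nM in this assay, at which 2 of the 3 values shown sit). Compound 4 is therefore expected to stay at that limit or beyond, with an estimated value of 100000 nM in this assay and a range from 50000 nM to 500000 nM. The expected step that the limit leaves unreadable from compound 3 to compound 4 is most likely to show up only as a limit again.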

Compound 4, half-maximal inhibitory concentration: > 50000 nM
Compound 4: no number, only a limit; the forecaster's own chance of this, stated with the estimate: 90%; the middle value lies beyond the limit too.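

In this assay, within the data shown here, compound 4 gives only a limit, > 50000 nM, and compound 3 also gives only a limit, so no step between compound 3 and compound 4 can be read. The compounds shown leave open how strongly either compound inhibits, and whether 4-hydroxyphenyl in place of 2-hydroxyphenyl makes any difference between these two: the limit of > 50000 nM in this assay, at which 3 of the 4 values shown sit.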